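Anilino in place of methylamino on a thienopyrimidine-type core

The compounds below may be only part of what the source reports. "The series", "measured", "known", "first", "only" and "open" are said of these compounds alone.

Measured compounds:
compound 1, `C(=C/c1ccco1)\c1nc(NCc2ccccc2)c2sccc2n1`: > 1000000 nM
compound 2, `CNc1nc(/C=C/c2cc(OC)c(OC)c(OC)c2)nc2ccsc12`: > 1000000 nM

In a functional assay on L02 cells (Homo sapiens) for inhibition, read by Griess assay, with stated times of 1 h and 24 h (on this read-out lower numbers stand for stronger inhibition and higher numbers for weaker inhibition), compound 2, whose structure is `CNc1nc(/C=C/c2cc(OC)c(OC)c(OC)c2)nc2ccsc12`, gives only a limit, > 1000000 nM. Compound 1, `C(=C/c1ccco1)\c1nc(NCc2ccccc2)c2sccc2n1`, likewise reaches only a limit in this assay, > 1000000 nM. Both values therefore sit at the limit of > 1000000 nM in this assay, at which 2 of the 2 values shown sit, and no real number places either compound on the scale. The values are not ordered against each other; both merely show inhibition too weak to be read.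

Compound 3, `COc1ccc(Nc2nc(/C=C/c3cc(OC)c(OC)c(OC)c3)nc3ccsc23)cc1`, is not yet measured. It differs from compound 2 by 4-methoxyphenyl in place of methyl on a nitrogen on an aromatic ring. Among the compounds with values here, no step between measured compounds is given, and neither measured compound offers a number to build on. With both measured compounds at the limit, it is expected that this change brings no step beyond the scatter, and the step from compound 2 to compound 3, an at least 1.2-fold lower number from compound 2 to compound 3 (0.09 log units; that floor lies within the scatter), is estimated as a small one at best. Compound 3 is expected to give about 800000 nM in this assay, within 50000 nM to 5000000 nM, and most likely again only a limit.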

Compound 3, half-maximal inhibitory concentration: 279000 nM
The estimate for compound 3 lay 2.9-fold (0.46 log units) above the measured number, within the range that was stated.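

In this assay, the change from methylamino to (4-methoxyphenyl)amino gives an at least 3.5-fold lower number from compound 2 to compound 3 (0.55 log units; beyond the scatter), a step beyond the scatter at a position where the earlier values offered no number to work from. Of the three compounds shown, only compound 3 has a real number on the scale, so this nitrogen on an aromatic ring is a place where a single change can make inhibition readable in this assay. The size of the step is only a floor, and its true size cannot be read, since the step starts from a limit and not from a number: the limit of > 1000000 nM in this assay, at which 2 of the 3 values shown sit.

The compounds shown leave open whether the step belongs to the aromatic ring itself or to its methoxy group, and an unsubstituted phenyl on the same nitrogen would separate the two. Also open, as far as these compounds go, is whether a cyclohexyl group, which has no aromatic ring, or a 4-fluorophenyl group would bring a similar step on that nitrogen with the rest of compound 3 kept unchanged.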